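A few compounds are considered here, and "the series" means these few. Any claim that something is new, unique, unknown or untested is made for them only; others in the source may bear on it.

Compounds measured so far:

Compound 1 `COc1ccc(-c2cc(NC(=O)c3ccccc3O)c[nH]c2=O)cc1`; its value in an ADME assay on HepG2 2.2.15 cells (Homo sapiens) for cytotoxicity, read by CCK-8 assay, with a stated time of 8 days (on this read-out higher numbers stand for lower toxicity in this test and lower numbers for higher toxicity in this test), is a limit of the assay, > 100000 nM.
Compound 2 `COc1ccc(-c2cc(NC(=O)c3ccc(OC)cc3O)c[nH]c2=O)cc1`; in this assay compound 2 gives 49900 nM.
Compound 3 `CCOc1ccc(-c2cc(NC(=O)c3ccccc3O)c[nH]c2=O)cc1`; in this assay compound 3 gives 41000 nM.

Two changes link these compounds. From compound 1 to compound 2 the difference is methoxy in place of hydrogen on an aromatic carbon, and in this assay this gave an at least 2.0-fold lower number from compound 1 to compound 2 (0.30 log units; that floor lies within the scatter); the starting point is a limit, as noted for compound 1 (the limit of > 100000 nM in this assay, at which 1 of the 3 values shown sits). The cores of compound 3 and compound 1 differ by methyl in place of hydrogen on a saturated chain carbon bound to an oxygen on an aromatic ring, which in this assay gave an at least 2.4-fold lower number from compound 1 to compound 3 (0.38 log units; beyond the scatter). Compound 3 and compound 2 sit close together in this assay, within the scatter of each other.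

Compound 4 `CCOc1ccc(-c2cc(NC(=O)c3ccc(OC)cc3O)c[nH]c2=O)cc1` has not been measured. It differs from compound 3 by methoxy in place of hydrogen on an aromatic carbon, the same change as from compound 1 to compound 2, at the same place. Since compound 3 already sits where compound 2 does in this assay, the step is expected to be smaller than an at least 2.0-fold lower number from compound 1 to compound 2 (0.30 log units; that floor lies within the scatter), estimated as a 1.6-fold lower number from compound 3 to compound 4 (0.21 log units; within the scatter). Compound 4 is accordingly estimated at 25000 nM in this assay, expected between 10000 nM and 60000 nM.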

Compound 4, half-maximal cytotoxic concentration: 69600 nM
Compound 4: middle estimate off by 2.8-fold (0.44 log units), on the low side, outside the stated range (above it).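

In this assay, methoxy in place of hydrogen on an aromatic carbon gave a 1.7-fold higher number from compound 3 to compound 4 (0.23 log units; within the scatter), and this step does not match the earlier one: the same change on two cores in this assay, an at least 2.0-fold lower number (0.30 log units; that floor lies within the scatter) from compound 1 to compound 2 and a 1.7-fold higher number (0.23 log units; within the scatter) from compound 3 to compound 4, at least 3.4-fold (0.53 log units) apart, beyond the scatter of two such steps
Methyl in place of hydrogen on a saturated chain carbon bound to an oxygen on an aromatic ring gave a 1.4-fold higher number from compound 2 to compound 4 (0.14 log units; within the scatter), and this step likewise parts from its earlier counterpart: the same change on two cores in this assay, an at least 2.4-fold lower number (0.38 log units; beyond the scatter) from compound 1 to compound 3 and a 1.4-fold higher number (0.14 log units; within the scatter) from compound 2 to compound 4, at least 3.4-fold (0.53 log units) apart, beyond the scatter of two such steps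
Among these compounds, both earlier steps start from compound 1, whose value of > 100000 nM is a limit of the assay, so their true size stays unknown, and these four compounds show only that neither change carried over at its first size, not why the steps differ.

The compounds shown leave open whether this mismatch extends beyond these two changes. As far as these compounds go, it also remains open how a propoxy chain in place of the ethoxy group, or an amine in place of the methoxy group of the 2-hydroxy-4-methoxyphenyl part, would read in this assay.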